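The source may report more compounds than this note shows. Statements on the series, on what has been measured and on what is new or still open speak of the compounds shown alone.

Measured in an ADME assay on HEK-293T cells (Homo sapiens) for cytotoxicity, read by CCK-8 assay, with a stated time of 48 h; a lower number here means a stronger inhibitor, a higher number a weaker inhibitor:
- Compound 1 `O=S(=O)(NCCNC(=S)Nc1cccc(Cl)c1)c1ccc(-c2ccccc2OCc2ccccc2)s1`: 10200 nM
- Compound 2 `O=[N+]([O-])c1ccc(NC(=S)NCCNS(=O)(=O)c2ccc(-c3ccccc3OCc3ccccc3)s2)cc1`: 8900 nM
- Compound 3 `O=[N+]([O-])c1cccc(NC(=S)NCCNS(=O)(=O)c2ccc(-c3ccccc3OCc3ccccc3)s2)c1`: 18300 nM

Compound 3 stands at the high end of this small set. The step of a 2.1-fold higher number from compound 2 to compound 3 (0.31 log units; beyond the scatter) is modest, while a 1.8-fold higher number from compound 1 to compound 3 (0.25 log units; within the scatter) does not clear the scatter.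

Compound 4 `O=S(=O)(NCCNC(=S)Nc1ccc(Cl)cc1)c1ccc(-c2ccccc2OCc2ccccc2)s1` has not yet been measured. It differs from compound 3 in one group: 4-chlorophenyl in place of 3-nitrophenyl on an amide-type nitrogen. In words, this is 4-chlorophenyl in place of 3-nitrophenyl on an amide-type nitrogen whose other neighbour is the thiocarbonyl carbon.

Among the measured compounds shown here, no measured pair makes exactly this change, so three steps serve as guides. Replacing chloro with nitro gave a 1.8-fold higher number from compound 1 to compound 3 (0.25 log units; within the scatter), and 3-nitrophenyl in place of 4-nitrophenyl gave a 2.1-fold higher number from compound 2 to compound 3 (0.31 log units; beyond the scatter). Read backwards, both point towards a lower number. The third step, a 1.1-fold lower number from compound 1 to compound 2 (0.06 log units; within the scatter), shows no separation between the two compounds it joins. All three steps are small, so only a small shift is expected, and it may not exceed the scatter.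

The expected change is a 1.7-fold lower number from compound 3 to compound 4 (0.22 log units; within the scatter).

For compound 4 the estimated value is 11000 nM, with an expected range of 5500 nM to 21000 nM.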

Compound 4, half-maximal inhibitory concentration: 12100 nM
The estimate for compound 4 lay 1.1-fold (0.04 log units) below the measured number; the measured number falls inside the stated range.
By their numbers in this assay, from the lowest: compounds 2, 1, 4 and 3 (each within the scatter of the next, the first and the last beyond it).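

In this assay, compound 4 places a 4-chlorophenyl group on the amide-type nitrogen whose other neighbour is the thiocarbonyl carbon, and each step that reaches it is small: a 1.5-fold lower number from compound 3 to compound 4 (0.18 log units; within the scatter), a 1.4-fold higher number from compound 2 to compound 4 (0.13 log units; within the scatter) and a 1.2-fold higher number from compound 1 to compound 4 (0.07 log units; within the scatter). Among the compounds shown here, the last of these is new information about this position, since it compares 3-chlorophenyl and 4-chlorophenyl directly and the two cannot be told apart, whereas the nitrophenyl pair gave the only step in the earlier set that cleared the scatter. Compound 4 also allows the exchange of chloro for nitro to be read twice, once with the group as in compound 1 and once with the group as in compound 4, and the two readings do not differ beyond what two such steps can scatter: the same change on two cores in this assay, a 1.8-fold higher number (0.25 log units; within the scatter) from compound 1 to compound 3 and a 1.4-fold lower number (0.13 log units; within the scatter) from compound 4 to compound 2, 2.4-fold (0.39 log units) apart, within the scatter of two such steps.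

Every compound shown carries a chloro or nitro group on this phenyl ring, so the effect of a methoxy group, an amine or a carboxylic acid there remains open. Also open, on these data alone, is whether a longer chain in the linker of the shared core would give a step beyond the scatter in this assay.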